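Swapping One Aromatic Group on Compound 2

The source may report more compounds than this note shows. Statements on the series, on what has been measured and on what is new or still open speak of the compounds shown alone.

Within the data shown here, in an ADME assay on HepG2 cells (Homo sapiens) for cytotoxicity (a higher number here means that more compound is tolerated, a lower number that less compound is tolerated), compound 2 (`CSc1cccc(N2C(=O)CN(c3cccc(C(F)(F)F)c3)CC2C(=O)NC2CCCC2)c1`) gives 20000 nM, the only actual number in this small set. Compound 1 (`CSc1cccc(N2C(=O)CN(c3ccccc3)CC2C(=O)NC2CCCC2)c1`) gives > 50000 nM, which is a limit of the assay. Compound 3 (`CSc1cccc(N2C(=O)CN(c3cccc(C#N)c3)CC2C(=O)NC2CCCC2)c1`) gives > 50000 nM, also a limit. Compound 2 is therefore the least tolerated of the three.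

Compound 4 (`CSc1cncc(N2C(=O)CN(c3cccc(C(F)(F)F)c3)CC2C(=O)NC2CCCC2)c1`) keeps the 3-(trifluoromethyl)phenyl group of compound 2 and changes the 3-(methylsulfanyl)phenyl group on an amide-type nitrogen in a ring: a group of 8 heavy atoms (6 carbon, 1 nitrogen, 1 sulfur; one six-membered aromatic ring with 1 hetero atom) in place of a group of 8 heavy atoms (7 carbon, 1 sulfur; one six-membered aromatic ring of carbon only), on an amide-type nitrogen in a ring.

The measured steps bear on this change only indirectly. They show an at least 2.5-fold lower number from compound 1 to compound 2 (0.39 log units; beyond the scatter) and an at least 2.5-fold higher number from compound 2 to compound 3 (0.39 log units; beyond the scatter), but both concern trifluoromethyl, and neither alters the group that changes here. They show that this assay can respond to a single substitution, but they give no size for this one. No step beyond the scatter is therefore expected, and the estimate is a 1.3-fold higher number from compound 2 to compound 4 (0.10 log units; within the scatter). For compound 4 the expected value is 25000 nM, with an estimated range from 12000 nM to 50000 nM.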

Compound 4, half-maximal cytotoxic concentration in the HepG2 assay: 26000 nM
Compound 4: the middle estimate sits 1.0-fold (0.02 log units) below what was measured; the measured number falls inside the stated range.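

In the HepG2 assay, placing the ring with one hetero atom on the amide-type nitrogen in place of 3-(methylsulfanyl)phenyl gives a 1.3-fold higher number from compound 2 to compound 4 (0.11 log units; within the scatter), so this assay does not separate the two compounds at this position. Compounds 1, 2 and 3 differ only in the substituent on the other aromatic group, so they gave no reading for this place, where the change does register in a physicochemical assay for solubility, at pH 6.8; a lower number here means a less soluble compound, a higher number a more soluble compound: the measured solubility of compound 2, 4000 nM, and of compound 4, 40000 nM, a 10-fold higher number (1.00 log units; beyond the scatter) In the physicochemical assay compound 2 gives 4000 nM, and compound 4 gives 40000 nM.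

The compounds shown leave open how either assay would respond if the ring on the amide-type nitrogen carried an amine or a carboxylic acid in place of its sulfur-bearing group. They also leave open whether the same ring exchange would give a similar result with the cyano group of compound 3 in place of trifluoromethyl.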